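A dihydroxyphenyl in place of a trimethoxyphenyl: compound 4

The compounds below may be only part of what the source reports. "The series", "measured", "known", "first", "only" and "open" are said of these compounds alone.

Of the compounds shown here, three sharing one core have been measured in a functional assay on MKN-45 cells (Homo sapiens) for cytotoxicity, read by MTT assay, with a stated time of 72 h; a lower number here means a stronger inhibitor, a higher number a weaker inhibitor. Compound 1 `CN(C)CCn1cnnc1-c1cc(Oc2ccc(NC(=O)N/N=C/c3c(Cl)cccc3Cl)cc2F)ccn1` gives 160 nM. Compound 3 `CN(C)CCn1cnnc1-c1cc(Oc2ccc(NC(=O)N/N=C/c3ccc(F)cc3F)cc2F)ccn1` gives 810 nM. Compound 2 `COc1ccc(/C=N/NC(=O)Nc2ccc(Oc3ccnc(-c4nncn4CCN(C)C)c3)c(F)c2)c(OC)c1OC` gives 2020 nM, the highest of the three numbers: its nearest neighbour is compound 3, with a 2.5-fold lower number from compound 2 to compound 3 (0.40 log units; beyond the scatter), and its furthest is compound 1, with a 13-fold higher number from compound 1 to compound 2 (1.10 log units; beyond the scatter) running the other way. The step of a 5.1-fold higher number from compound 1 to compound 3 (0.70 log units; beyond the scatter) completes the set.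

Compound 4 `CN(C)CCn1cnnc1-c1cc(Oc2ccc(NC(=O)N/N=C/c3ccc(O)cc3O)cc2F)ccn1` differs from compound 2 in one place: 2,4-dihydroxyphenyl in place of 2,3,4-trimethoxyphenyl on a carbon with a double bond to nitrogen. Among the measured compounds shown here, no measured step involves a 2,4-dihydroxyphenyl, so the three known steps bear on it only indirectly. They show that the group on the carbon with a double bond to nitrogen moves the number well beyond the scatter, and that compound 2 with its 2,3,4-trimethoxyphenyl sits at the weak end, as a 2.5-fold lower number from compound 2 to compound 3 (0.40 log units; beyond the scatter) and a 13-fold higher number from compound 1 to compound 2 (1.10 log units; beyond the scatter) make plain. As compound 2 gave 2020 nM, the weakest of the three, a modest move toward a lower number is expected, though a change within the scatter cannot be excluded. Compound 4 is therefore estimated at 1000 nM, between 250 nM and 4000 nM. This amounts to an expected 2.0-fold lower number from compound 2 to compound 4 (0.31 log units; beyond the scatter).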

Compound 4, half-maximal inhibitory concentration: 2860 nM
Beside the measured number, compound 4's estimate is 2.9-fold (0.46 log units) below it; the range from low to high includes it.
By their numbers in this assay, from the lowest: compound 1; then compound 3; then compounds 2 and 4 (each within the scatter of the next).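

In this assay, the exchange of 2,3,4-trimethoxyphenyl for 2,4-dihydroxyphenyl on the carbon with a double bond to nitrogen gives a 1.4-fold higher number from compound 2 to compound 4 (0.15 log units; within the scatter), so a group with 2 hydrogen-bond donors and one with 0 hydrogen-bond donors cannot be told apart at this position, even though the heavy atom count falls. The halogen-bearing groups stay clearly separate from the new group, with a 3.5-fold higher number from compound 3 to compound 4 (0.55 log units; beyond the scatter) for the 2,4-difluorophenyl compound and an 18-fold higher number from compound 1 to compound 4 (1.25 log units; beyond the scatter) for the 2,6-dichlorophenyl compound, and among these four compounds both halogen-bearing groups give lower numbers than both oxygen-bearing groups, with no compound going against this. Nothing given here accounts for this division between the groups.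

The compounds shown leave open whether the lower numbers follow the halogen itself or its placement on the ring, which a 2,6-difluorophenyl or a 2,4-dichlorophenyl group would help to separate. They also leave open how a 2,4-dimethoxyphenyl group or a phenyl group with no substituent would compare at this position.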